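This account rests on a few compounds, and the source may have more. Where it says the series, first, only, none or still open, it means among the compounds named here.

Measured compounds and their numbers in an ADME assay on HepG2 cells (Homo sapiens) for cytotoxicity, read by luminescence, CellTiter-Glo and ATP content, with a stated time of 72 h; on this read-out higher numbers stand for an effect only at larger amounts of compound and lower numbers for an effect already at smaller amounts: compound 1 `Cc1cc(C)cc(Cc2ccc3c(NCCCNCc4ccco4)ccnc3c2)c1` gives 6270 nM; compound 2 `CN(C)c1cccc(Oc2ccc3c(NCCCNCc4ccco4)ccnc3c2)c1` gives 16000 nM; compound 3 `Fc1ccc(Cc2ccc3c(NCCCNCc4ccco4)ccnc3c2)c(Cl)c1` gives 5730 nM.

Compound 3 holds the lowest of the three numbers in this assay, but the gap to compound 1 is within the scatter, and only compound 2 sits clearly apart from it. The step to compound 4 `c1coc(CNCCCNc2ccnc3cc(-c4cccc5ccccc45)ccc23)c1` changes the same position that varies among the measured compounds: naphthalen-1-yl in place of 2-chloro-4-fluorobenzyl on an aromatic carbon. For the measured compounds named here, two measured steps bear on it. The step of a 1.1-fold lower number from compound 1 to compound 3 (0.04 log units; within the scatter) shows that exchanging one benzyl for another leaves the number where it is. Going by the values given here, the step of a 2.8-fold lower number from compound 2 to compound 3 (0.45 log units; beyond the scatter) and the step of a 2.6-fold higher number from compound 1 to compound 2 (0.41 log units; beyond the scatter) show that a phenoxy group bearing a dimethylamino substituent moves the number modestly upward, and only that change does so. Among the compounds with values here, the naphthalen-1-yl group in compound 4 is neither a benzyl nor a phenoxy group, so no measured step matches it directly; it contains only carbon and no heteroatom, which places it closer to the benzyl pair than to compound 2. Compound 4 is therefore expected to stay near compound 3, with the step of a 1.1-fold lower number from compound 3 to compound 4 (0.06 log units; within the scatter) within the scatter. The estimated value for compound 4 in this assay is 5000 nM, within a range of 2000 nM to 14000 nM.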

Compound 4, half-maximal effective concentration: 5600 nM
Beside the measured number, compound 4's estimate is 1.1-fold (0.05 log units) below it; low and high end bracket the measured number.
By their numbers in this assay, from the lowest: compounds 4, 3 and 1 (each within the scatter of the next); then compound 2.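

In this assay, for the compounds shown here, the earlier compounds carried only groups with one six-membered aromatic ring at this position, and naphthalen-1-yl now adds a second such ring and gives a 1.0-fold lower number from compound 3 to compound 4 (0.01 log units; within the scatter) and a 1.1-fold lower number from compound 1 to compound 4 (0.05 log units; within the scatter). Both steps lie within the scatter, so the number stays put whether this aromatic carbon carries naphthalen-1-yl, 2-chloro-4-fluorobenzyl or 3,5-dimethylbenzyl, and the loss of the chlorine and fluorine of compound 3 leaves no readable mark. Going by these compounds alone, the step of a 2.9-fold lower number from compound 2 to compound 4 (0.46 log units; beyond the scatter) lies beyond the scatter, which leaves compound 2, with its 3-(dimethylamino)phenoxy group, as the only one of the four compounds set apart, though no information given here accounts for that difference or for the closeness of the other three.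

The compounds shown do not separate the ether oxygen of compound 2 from its dimethylamino group, since neither a plain phenoxy group nor a 3-(dimethylamino)benzyl group stands among them. On these data alone, how a carboxylic acid or a pyridin-3-yl group at this position would read in this assay also remains open.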